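Bicyclic amines with small heteroaryl groups: cytotoxicity on kidney cells

A few compounds are considered here, and "the series" means these few. Any claim that something is new, unique, unknown or untested is made for them only; others in the source may bear on it.

Measured compounds:
compound 1, `C[C@H]1[C@H](NCc2sccc2-c2ccsc2)C[C@H]2C[C@@H]1C2(C)C`: 12500 nM
compound 2, `C[C@H]1[C@H](NCc2ccoc2)C[C@H]2C[C@@H]1C2(C)C`: > 100000 nM

Two compounds share a bicyclic amine core and differ in the heteroaryl group attached to the chain carbon bound to the amine nitrogen. In an ADME assay on MDCK cells (Canis lupus familiaris) for cytotoxicity, read by microscopy, with a stated time of 48 h (on this read-out higher numbers stand for lower toxicity in this test and lower numbers for higher toxicity in this test), compound 1 gives 12500 nM. Compound 2 gives only a limit, > 100000 nM, so its true value is not a number but sits at the limit of > 100000 nM in this assay, at which 1 of the 2 values shown sits. Compound 3, `C[C@H]1[C@H](NCc2nccs2)C[C@H]2C[C@@H]1C2(C)C`, has not yet been tested; it differs from compound 2 by 1,3-thiazol-2-yl in place of furan-3-yl on a saturated chain carbon bound to an amine nitrogen. Among the compounds with values here, because compound 2 stands at the limit, no measured step is available to guide an expectation, and no step beyond the usual scatter is expected in this assay for so small a change. Compound 3 is expected to give 100000 nM, with a range from 30000 nM to 200000 nM. The estimated step is a number no higher from compound 2 to compound 3 (the limit leaves the size open), most probably again reported as a limit.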

Compound 3, minimum cytotoxic concentration: > 100000 nM
Compound 3 was reported as a limit; the forecaster's own chance of this, stated with the estimate: 60%; the middle value sits exactly at the limit.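

In this assay compound 2 and compound 3 both stand as limits, so no step can be read between them: the limit of > 100000 nM in this assay, at which 2 of the 3 values shown sit.

Going by these compounds, how far either compound lies from that limit stays open, as does whether 1,3-thiazol-2-yl in place of furan-3-yl changes the read-out at all.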